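A few compounds are considered here, and "the series" means these few. Any claim that something is new, unique, unknown or untested is made for them only; others in the source may bear on it.

Compound 1 `CCc1ccc2ncn(-c3ccnc(N)n3)c2c1` gives 79400 nM in an assay on Sf9 cells for inhibition of mitogen-activated protein kinase kinase kinase 14 variant S549D (Homo sapiens), with a stated time of 30 min, in the presence of a further agent that is not named here; a lower number here means a stronger inhibitor, a higher number a weaker inhibitor.
Compound 2 `C=CC(=O)NCCCc1ccc2ncn(-c3ccnc(N)n3)c2c1` gives 501000 nM in this assay.
Compound 3 `C#Cc1cc(C#Cc2ccc3ncn(-c4ccnc(N)n4)c3c2)ccn1` gives 31600 nM in this assay.

All three compounds share the same core and are weak inhibitors in this assay. Compound 3 has the lowest number of the three: compound 1 comes nearest, and compound 2 lies furthest away, both steps being beyond the usual scatter.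

Compound 4 `Cc1ccnc(C#Cc2ccc3ncn(-c4ccnc(N)n4)c3c2)n1` differs from compound 3 at the triple bond that hangs from the shared core: a group of 7 heavy atoms (5 carbon, 2 nitrogen; one six-membered aromatic ring with 2 hetero atoms) in place of a group of 8 heavy atoms (7 carbon, 1 nitrogen; one six-membered aromatic ring with 1 hetero atom), on a triple-bonded carbon.

Among the compounds with values here, only one step among the measured compounds is known, a 6.3-fold higher number from compound 1 to compound 2 (0.80 log units; beyond the scatter), and it concerns an amide-bearing chain on the core, not the group at the end of the triple bond. Within the data shown here, no measured step therefore bears directly on the change from compound 3 to compound 4. Both compound 3 and compound 4 keep the triple bond and a six-membered aromatic ring at its end, so the change is expected to be small, most likely within the scatter, in either direction.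

Compound 4 is therefore expected to give about 31600 nM in this assay, with a range from 8000 nM to 125000 nM, which corresponds to an estimated step of no change at the digits printed from compound 3 to compound 4 (within the scatter).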

Compound 4, half-maximal inhibitory concentration: 1580 nM
For compound 4 the middle estimate is 20-fold (1.30 log units) above the measured one, and the stated range ends above it.
By their numbers in this assay, from the lowest: compound 4; then compound 3; then compound 1; then compound 2.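

The group at the end of the triple bond matters far more in this assay than a shared ring type would suggest: with 4-methylpyrimidin-2-yl on the triple-bonded carbon, the result is a 20-fold lower number from compound 3 to compound 4 (1.30 log units; beyond the scatter), the largest step among these compounds. Both groups carry a six-membered aromatic ring, so having a ring of that size at this position does not by itself set the number; what the ring carries and which atoms it contains are tied to a large difference. Nothing measured here explains why this exchange has so large an effect.

The exchange alters several things at once: the entering ring has one more nitrogen and a methyl, and the leaving group's own triple bond is gone, so these compounds cannot show which of those changes accounts for the step. A pyrimidin-2-yl group without the methyl, or one with an amine or a methoxy group in place of the methyl, would help separate these contributions and show how much room this position offers.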